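Vero cytotoxicity notes: from compound 2 to compound 3

The compounds below may be only part of what the source reports. "The series", "measured", "known", "first", "only" and "open" are said of these compounds alone.

compound 1 `CCOCCOC(=O)Nc1cc2nc(C3CCCCC3)[nH]c2cc1N(C)C`: > 100 ug/mL
compound 2 `CCN(CC)c1cc2[nH]c(C3CCCCC3)nc2cc1NC(=O)c1ccc(F)cc1`: > 100 ug/mL

In an ADME assay on Vero cells (Chlorocebus sabaeus) for cytotoxicity, read by resazurin assay, with a stated time of 3 days (on this read-out lower numbers stand for stronger inhibition and higher numbers for weaker inhibition), compound 1 reaches only the assay limit, > 100 ug/mL. Compound 2 likewise sits at the limit, > 100 ug/mL, in this assay. Both values fall at the limit of > 100 ug/mL in this assay, at which 2 of the 2 values shown sit, so no cytotoxic potency is resolved for either. Compound 3 `CCN(CC)c1cc2[nH]c(C3CCCCC3)nc2cc1NC(=O)NCc1ccccc1` differs from compound 2 by benzylamino in place of 4-fluorophenyl on a carbonyl carbon. For the measured compounds named here, no measured pair bears on this change; the step that the limit leaves unreadable from compound 2 to compound 3 is expected to stay within the scatter, with no direction. Compound 3 is estimated at 150 ug/mL (70 ug/mL to 300 ug/mL) in this assay, most likely again reported only as a limit.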

Compound 3, half-maximal inhibitory concentration: > 100 ug/mL
Compound 3 was reported as a limit; the forecaster's own chance of this, stated with the estimate: 80%; the middle value is on the limit's open side.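

For the compounds shown here, compound 3 is again only a limit (> 100 ug/mL), and no step from compound 2 to compound 3 can be read: the limit of > 100 ug/mL in this assay, at which 3 of the 3 values shown sit. On these data alone, what concentration, if any, is cytotoxic for these compounds in this assay remains open.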